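Benzofuranyl for fluorophenyl on the alkyne of compound 1

The compounds below may be only part of what the source reports. "The series", "measured", "known", "first", "only" and "open" are said of these compounds alone.

Compound 1 `CNC(=O)[C@@]12C[C@@H]1[C@@H](n1cnc3c(NC)nc(C#Cc4cccc(F)c4)nc31)[C@H](O)[C@@H]2O` and compound 2 `CNC(=O)[C@@]12C[C@@H]1[C@@H](n1cnc3c(NC)nc(C#Cc4ncccn4)nc31)[C@H](O)[C@@H]2O` share one core and differ only in the group on the triple-bonded carbon. In an assay on CHO cells for displacement of a labelled ligand from adenosine receptor A1 (Homo sapiens), read by scintillation counting, with a stated time of 60 min, tested at 10 uM (on this read-out higher numbers stand for more inhibition at the one concentration tested (going by the name of the read-out) and lower numbers for less inhibition), compound 1 gives 14%, the lowest of the two numbers shown, and compound 2 gives 25%. For the measured compounds named here, the one step measured, a number 11 percentage points higher from compound 1 to compound 2 (beyond the scatter), comes from pyrimidin-2-yl in place of 3-fluorophenyl on a triple-bonded carbon. Compound 3 `CNC(=O)[C@@]12C[C@@H]1[C@@H](n1cnc3c(NC)nc(C#Cc4cc5ccccc5o4)nc31)[C@H](O)[C@@H]2O` is the unmeasured partner of compound 1, and the change is 1-benzofuran-2-yl in place of 3-fluorophenyl on a triple-bonded carbon. Going by the values given here, no measured step swaps in 1-benzofuran-2-yl, so the step to compound 2 bears on it only loosely, showing that a replacement at this position moves the number modestly. Compound 3 is therefore expected to land near 20%, within 0% to 45%. The expected step of a number 6 percentage points higher from compound 1 to compound 3 (within the scatter) is estimated to stay within the scatter.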

Compound 3, a percentage reported as inhibition, at one concentration (the size of the read-out at that concentration, not a potency): 13%
Estimate against measurement, compound 3: 7 percentage points above; the measured number falls inside the stated range.
By their numbers in this assay, from the lowest: compounds 3 and 1 (each within the scatter of the next); then compound 2.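

In this assay the change to 1-benzofuran-2-yl gives a number 1 percentage points lower from compound 1 to compound 3 (within the scatter) and so, on a triple-bonded carbon, a group of two aromatic rings with one hydrogen-bond acceptor cannot be told apart from the single ring of 3-fluorophenyl. Set against pyrimidin-2-yl, the same group gives a number 12 percentage points lower from compound 2 to compound 3 (beyond the scatter) and this leaves compound 2 apart from both other compounds, a separation that one step alone could not show. Nothing at hand explains why the number responds to one replacement and not to the other.

As far as these compounds go, what remains open is whether pyridin-2-yl or another nitrogen-containing ring would stay with pyrimidin-2-yl or fall with the other two groups. The compounds shown also say nothing about an amine or a carboxylic acid at the end of a longer chain on the triple-bonded carbon.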